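Two ring stereocentres inverted at an assay limit

The source may report more compounds than this note shows. Statements on the series, on what has been measured and on what is new or still open speak of the compounds shown alone.

In an ADME assay on Jejunum (Mus musculus, strain C57BL/6) for metabolic stability, read by HPLC, with a stated time of 12 h (on this read-out lower numbers stand for a shorter-lived compound and higher numbers for a longer-lived compound), compound 2 (`O=C(O)[C@H](CO)NC(=O)[C@H]1C[C@@H](O)CN1`) gives > 12 h as a limit of the assay and not a number. Compound 1 (`O=C(O)[C@@H](CO)NC(=O)[C@H]1C[C@@H](O)CN1`) gives > 12 h which is likewise a limit. Compound 3 (`O=C(O)[C@H](CO)NC(=O)[C@@H]1C[C@H](O)CN1`) is reached from compound 2 through the two compounds have the same atoms and bonds and differ only in configuration as drawn: 2 of 3 stereo elements differ; a stereocentre at a saturated ring carbon is drawn R in compound 2 and S in compound 3; a stereocentre at a saturated ring carbon is drawn R in compound 2 and S in compound 3 and has not yet been measured. For the measured compounds named here, the one measured step is a step that the two limits leave unreadable from compound 1 to compound 2 and it concerns a saturated chain carbon and not a ring carbon. As far as these compounds go, its size stays open because of the limit of > 12 h in this assay, at which 2 of the 2 values shown sit, and its only bearing on the new change is the fact that compounds 1 and 2 differ only in the configuration as drawn as a comparable kind of pair. No direction can be read from it. The expected step is a step that the limit leaves unreadable from compound 2 to compound 3 and nothing beyond the usual scatter is expected in this assay for now. Compound 3 is expected at 14 h with an estimated range from 8 h to 24 h and a report as a limit is the likeliest outcome.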

Compound 3, half-life: 0.35 h
The estimate for compound 3 lay 40-fold (1.60 log units) above the measured number; the measured number lies below the stated range.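

In this assay, inverting the two ring stereocentres gives an at least 34-fold lower number from compound 2 to compound 3 (1.53 log units; beyond the scatter), so the configuration at the ring carbons shows in this read-out, which the earlier pair, differing only at a saturated chain carbon, could not show. Because no atom or bond changes, this drop can be traced to configuration alone: the fact that compounds 2 and 3 differ only in the configuration as drawn. Inverting all three stereocentres gives an at least 34-fold lower number from compound 1 to compound 3 (1.53 log units; beyond the scatter), and this mirror-image pair likewise changes in nothing else: the fact that compounds 1 and 3 differ only in the configuration as drawn.

As far as these compounds go, the step between compound 1 and compound 2 cannot be read, as both values are limits of the assay, and the two ring stereocentres changed together, so the share of each stereocentre stays open. Also open, from the compounds shown here alone, is how an amine in place of the ring hydroxyl would read in this assay.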